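Swapping nitro for cyano on a shared core

The source may hold more compounds than are shown below. What is called first, only, known or untested is meant among the compounds shown, and "the series" means these compounds.

Measured values in a functional assay (thoracic aorta, Rattus norvegicus, strain Wistar); on this read-out higher numbers stand for an effect only at larger amounts of compound and lower numbers for an effect already at smaller amounts:
Compound 1, `CC(C)NC(=O)Nc1nc2ccc([N+](=O)[O-])cc2s1`: 15700 nM
Compound 2, `CC(C)(C)NC(=O)Nc1nc2ccc([N+](=O)[O-])cc2s1`: 10800 nM
Compound 3, `CCc1ccc2nc(NC(=O)Nc3ccc(C(F)(F)F)cc3Cl)sc2c1`, is reported only as a limit of the assay: > 100000 nM

Compound 2 has the lowest of the two numbers; its nearest neighbour is compound 1, and the step between them, a 1.5-fold lower number from compound 1 to compound 2 (0.16 log units; within the scatter), is too small to count as a real difference. Compound 3 contributes only (the limit of > 100000 nM in this assay, at which 1 of the 3 values shown sits), so it gives no number to compare.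

Compound 4, `CC(C)(C)NC(=O)Nc1nc2ccc(C#N)cc2s1`, differs from compound 2 in one place: cyano in place of nitro on an aromatic carbon. Among the compounds with values here, none of the measured steps touches this change. Within the data shown here, the only measured step, a 1.5-fold lower number from compound 1 to compound 2 (0.16 log units; within the scatter), concerns a different part of the molecule and lies within the scatter, so the data offer no guide to the direction or size of the new step. The expectation is therefore no change beyond the scatter, with wide uncertainty. For compound 4 the expected value in this assay is 12000 nM, ranging from 4000 nM to 40000 nM. The step this estimate implies is a 1.1-fold higher number from compound 2 to compound 4 (0.05 log units; within the scatter).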

Compound 4, half-maximal effective concentration: 2780 nM
Estimate against measurement, compound 4: 4.3-fold (0.64 log units) above, and the stated range ends above it.
By their numbers in this assay, from the lowest: compound 4; then compounds 2 and 1 (each within the scatter of the next). At a limit, above all of these: compound 3.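

In this assay, within the data shown here, this swap gives the first step that lies beyond the scatter: a 3.9-fold lower number from compound 2 to compound 4 (0.59 log units; beyond the scatter). The group on this aromatic carbon therefore matters more here than the earlier change on the saturated chain, and nitro is not required for a measurable effect on the shared core. The size of the gain is modest, and nothing shown here accounts for it.

As far as these compounds go, the swap rests on a single pair, so it remains open whether cyano would give a similar step when combined with the chain of compound 1. From the compounds shown here alone, it is also open how a carboxylic acid, a primary amide, a methyl sulfone or a plain hydrogen on this aromatic carbon would compare with cyano.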